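Imidazopyrazine series: ethyl to formyl on the pendant phenyl

The source may hold more compounds than are shown below. What is called first, only, known or untested is meant among the compounds shown, and "the series" means these compounds.

Measured so far:
- compound 1, `Clc1ccc(-c2cn3ccnc3c(-c3ccc4ncn(C5CCCCC5)c4c3)n2)cc1`: 36.7%
- compound 2, `CCc1ccc(-c2cn3ccnc3c(-c3ccc4ncn(Cc5ccccc5)c4c3)n2)cc1`: 50.9%

In a functional assay on MDA-MB-435 cells (Homo sapiens) for inhibition, read by sulforhodamine B assay, with a stated time of 48 h, tested at 10 uM (a higher number here means more inhibition at the concentration tested (going by the name of the read-out), a lower number less inhibition), compound 2 gives 50.9%, the highest of the two numbers in hand. The nearest is compound 1 with 36.7%, which lies lower by a margin beyond the usual scatter. Within the data shown here, compound 1 and compound 2 differ in more than one place, so no single step between them is set out.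

Compound 3, `O=Cc1ccc(-c2cn3ccnc3c(-c3ccc4ncn(Cc5ccccc5)c4c3)n2)cc1`, is not yet measured. It differs from compound 2 in one place: formyl in place of ethyl on an aromatic carbon. Among the measured compounds shown here, no measured pair shows this change, so the size of the step is an open question. The expectation is a small step from compound 2 to compound 3 in this assay, downward or none beyond the scatter, estimated as a number 10.9 percentage points lower from compound 2 to compound 3 (beyond the scatter). For compound 3 the estimate in this assay is 40%, within a range from 20% to 60%.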

Compound 3, a percentage reported as inhibition, at one concentration (the size of the read-out at that concentration, not a potency): 13%
Beside the measured number, compound 3's estimate is 27 percentage points above it; measured number below the stated range.
By their numbers in this assay, from the lowest: compound 3; then compound 1; then compound 2.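

In this assay, among these compounds, the change from 4-ethylphenyl to 4-formylphenyl gives the first single-place step, and it is a large one: a number 37.9 percentage points lower from compound 2 to compound 3 (beyond the scatter). The position, an aromatic carbon para to a large group, is therefore sensitive to the group it carries, even though ethyl and formyl have the same number of heavy atoms and differ in carbon against oxygen, a double bond outside the aromatic rings and a hydrogen-bond acceptor. No measurement here accounts for the size of this step.

On these data alone, it remains open whether the step belongs to formyl alone or extends to other groups at this carbon, such as hydroxymethyl, a carboxylic acid or an amine. A longer alkyl chain in place of ethyl would show whether the value also moves among carbon-only groups.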